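Dichloro on the phenyl of compound 1

The source may report more compounds than this note shows. Statements on the series, on what has been measured and on what is new or still open speak of the compounds shown alone.

Compound 1 `COc1nc(-c2nc3ccccc3n2C)cc(-c2ccccc2)c1C#N` stands second highest of the three numbers in a functional assay on aorta (Rattus norvegicus, strain Wister) (on this read-out lower numbers stand for stronger inhibition and higher numbers for weaker inhibition), where compound 1 gives 300000 nM. Its nearest neighbour is compound 3 `CCOc1nc(-c2nc3ccccc3n2C)cc(-c2ccc(Cl)cc2)c1C#N`, which gives 293000 nM. The furthest is compound 2 `CCOc1nc(-c2nc3ccccc3n2C)cc(-c2ccccc2)c1C#N`, which gives 364000 nM. All three lie within the scatter of one another, so no order among them can be read.

The step to compound 4 `COc1nc(-c2nc3ccccc3n2C)cc(-c2ccc(Cl)cc2Cl)c1C#N` is 2,4-dichlorophenyl in place of phenyl on an aromatic carbon. Among the measured compounds shown here, two measured steps touch this change. a 1.2-fold higher number from compound 1 to compound 2 (0.08 log units; within the scatter) alters the alkoxy group rather than the phenyl and stays within the scatter. a 1.2-fold lower number from compound 2 to compound 3 (0.09 log units; within the scatter) places a single chloro on the phenyl and is likewise within the scatter. For the measured compounds named here, compound 4 carries the 2,4-dichlorophenyl and keeps the methoxy of compound 1; no measured step covers the dichloro pattern itself.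

On this basis no step beyond the scatter is expected, and the step from compound 1 to compound 4 is estimated as a 1.2-fold lower number from compound 1 to compound 4 (0.06 log units; within the scatter). Compound 4 is therefore expected to give 260000 nM in this assay. Going by the values given here, the expected range for compound 4 runs from 100000 nM to 700000 nM, kept wide because the only supporting evidence is a 1.2-fold lower number from compound 2 to compound 3 (0.09 log units; within the scatter).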

Compound 4, half-maximal inhibitory concentration: 214000 nM
Estimate against measurement, compound 4: 1.2-fold (0.08 log units) above; the range from low to high includes it.
By their numbers in this assay, from the lowest: compounds 4, 3, 1 and 2 (each within the scatter of the next).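

Replacing phenyl with 2,4-dichlorophenyl at this aromatic carbon, ortho to a cyano group and opposite the ring nitrogen, gives in this assay a 1.4-fold lower number from compound 1 to compound 4 (0.15 log units; within the scatter) and so does not separate the two compounds. Among the compounds shown here, the earlier single-chloro step was read only with the ethoxy group in place, so this is the first reading of a chlorinated phenyl with the methoxy group and of the dichloro pattern at this position: in this series, a phenyl carrying two chlorine atoms is tolerated here without a step beyond the scatter, and compound 4 stays at 214000 nM. No supporting data are available to explain this result.

From the compounds shown here alone, it remains open whether any substituent on this phenyl can produce a step beyond the scatter in this assay, for example an amine or a carboxylic acid in place of the chlorine atoms. Also unresolved is how a longer chain in place of the methoxy group would read, and whether a single chloro on the phenyl of compound 1 would read any differently from the dichloro pattern of compound 4.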